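A few compounds are considered here, and "the series" means these few. Any claim that something is new, unique, unknown or untested is made for them only; others in the source may bear on it.

Working notes on the cyclic peptide series. Of the compounds shown here, two have numbers so far. Compound 1, `CC(C)C[C@@H]1NC(=O)[C@H](CC(C)C)NC(=O)[C@H](CC(C)C)NC(=O)[C@@H](Cc2c[nH]c3ccccc23)NC(=O)[C@H](CC(C)C)NC1=O`, gives 30% in a functional assay on BXPC-3 cells (Homo sapiens) for inhibition, tested at 5 uM; on this read-out higher numbers stand for more inhibition at the one concentration tested (going by the name of the read-out) and lower numbers for less inhibition. Compound 2, `CC(C)C[C@@H]1NC(=O)[C@H](Cc2ccccc2)NC(=O)[C@H](CC(C)C)NC(=O)[C@@H](CO)NC(=O)[C@H](CC(C)C)NC1=O`, gives 22% in this assay. Compound 2 holds the lower of the two numbers, but the gap to compound 1 is within the usual scatter, so no ordering between them is claimed.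

The next compound to be run is compound 3, `CC[C@H]1NC(=O)[C@H](CC(C)C)NC(=O)[C@H](CC(C)C)NC(=O)[C@H](Cc2ccccc2)NC(=O)[C@H](CC(C)C)NC1=O`. It differs from compound 2 by methyl in place of hydroxy on a saturated chain carbon bound to a saturated ring carbon. Within the data shown here, no pair of measured compounds shows this change or any single change, so there is no measured step to lean on; the only guidance is that the two measured compounds, which differ from each other in more than one place, sit within the scatter of each other.

On that basis, a small step is expected from compound 2 to compound 3 in this assay, not clearly beyond the scatter in either direction, that is a number 3 percentage points higher from compound 2 to compound 3 (within the scatter). Compound 3 is estimated at 25% in this assay, with a range from 10% to 42%.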

Compound 3, a percentage reported as inhibition, at one concentration (the size of the read-out at that concentration, not a potency): 17%
The estimate for compound 3 lay 8 percentage points above the measured number; low and high end bracket the measured number.
By their numbers in this assay, from the lowest: compounds 3, 2 and 1 (each within the scatter of the next, the first and the last beyond it).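

Among these compounds, this is the first step that isolates a single change: on a saturated chain carbon bound to a saturated ring carbon, methyl in place of hydroxy gives a number 5 percentage points lower from compound 2 to compound 3 (within the scatter) in this assay. Cut one bond further out, the same difference reads hydroxymethyl to ethyl, and it removes the hydrogen-bond donor and acceptor counted for hydroxy; since the step stays within the scatter, this pair gives no sign that the hydroxy matters for the inhibition read at the one concentration tested. Nothing on hand explains the size of this step.

Still open is whether any group at this place would move the number beyond the scatter, since an amine, a carboxylic acid and a longer chain such as butyl are not among the compounds shown. Also open, as far as these compounds go, is whether the change from hydroxy to methyl would give a similar step at another position on the shared core, as this single pair speaks only for this one place.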